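Swapping the aryl group on the shared thiophene core

The source may report more compounds than this note shows. Statements on the series, on what has been measured and on what is new or still open speak of the compounds shown alone.

Compound 1 `Nc1scc(-c2ccc(I)cc2)c1C(=O)c1ccccc1`: 50%
Compound 2 `Nc1scc(-c2cccc(Cl)c2)c1C(=O)c1ccc(Cl)cc1`: 75%

In a functional assay on CHO cells for agonist activity at adenosine receptor A1 (Homo sapiens), read by fluorescence and ERK phosphorylation, with stated times of 30 min and 1.5 h, tested at 10 uM (on this read-out lower numbers stand for a weaker effect and higher numbers for a stronger effect at the one concentration tested), compound 2 gives 75%, the higher of the two numbers measured; compound 1 gives 50%, a gap beyond the usual scatter. Compound 3 `Nc1scc(-c2ccc(I)cc2)c1C(=O)c1ccc(Cl)cc1` differs from compound 2 in one place: 4-iodophenyl in place of 3-chlorophenyl on an aromatic carbon. Compound 1 carries the same 4-iodophenyl group and sits lower, so the step of a number 15 percentage points lower from compound 2 to compound 3 (beyond the scatter) is expected to be downward, of moderate size. Compound 3 is therefore estimated at 60%, within a range from 35% to 85%.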

Compound 3, a percentage reported as activity, at one concentration (the size of the read-out at that concentration, not a potency): 61%
Compound 3: the middle estimate sits 1 percentage points below what was measured; the measured number falls inside the stated range.
By their numbers in this assay, from the lowest: compound 1; then compound 3; then compound 2.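

In this assay compound 3 splits the gap between the earlier pair into two single changes. Swapping the aryl group on the shared core gives a number 14 percentage points lower from compound 2 to compound 3 (beyond the scatter) while the rest stays the same, and chloro in place of hydrogen on an aromatic carbon gives a number 11 percentage points higher from compound 1 to compound 3 (beyond the scatter) with 4-iodophenyl kept, so each change alone moves the number. Nothing available explains either step. The swap from 3-chlorophenyl to 4-iodophenyl alters both the halogen and where it sits on the phenyl ring, and these two stay unseparated. As far as these compounds go, how an amine or a carboxylic acid on that aromatic carbon would read remains open.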